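The source may hold more compounds than are shown below. What is called first, only, known or untested is meant among the compounds shown, and "the series" means these compounds.

Measured compounds:
Compound 1 `CC1(C)CC(=O)C(C(=S)SCc2ccccc2)=C(Nc2ccc(Cl)cc2Cl)C1`: in a functional assay on PBMC cells (Homo sapiens) for inhibition, read by ELISA, with a stated time of 18 h (a lower number here means a stronger inhibitor, a higher number a weaker inhibitor), compound 1 gives > 20 ug/mL, which is a limit of the assay and not a number.
Compound 2 `CC1(C)CC(=O)C(C(=S)SCCO)=C(Nc2ccc(Cl)cc2Cl)C1`: in this assay compound 2 gives > 20 ug/mL, again only a limit.
Compound 3 `CC1(C)CC(=O)C(C(=S)SCc2ccccc2)=C(Nc2ccc(Br)cc2)C1`: in this assay compound 3 gives > 20 ug/mL, again only a limit.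

Compound 2 differs from compound 1 by hydroxymethyl in place of phenyl on a saturated chain carbon bound to a sulfur. Compound 3 differs from compound 1 by 4-bromophenyl in place of 2,4-dichlorophenyl on an amine nitrogen. Neither step can be sized: a step that the two limits leave unreadable from compound 1 to compound 2 and a step that the two limits leave unreadable from compound 1 to compound 3 both remain unreadable because of the limit of > 20 ug/mL in this assay, at which 3 of the 3 values shown sit.

Compound 4 `CC1(C)CC(=O)C(C(=S)SCCO)=C(Nc2ccc(Br)cc2)C1` has not yet been measured. It differs from compound 3 by hydroxymethyl in place of phenyl on a saturated chain carbon bound to a sulfur, which is the same change as that from compound 1 to compound 2, made at the same place. That change has already been made once between two compounds that both sit at the limit, and compound 3 itself sits there, so the expected step is a step that the limit leaves unreadable from compound 3 to compound 4, resting on (the limit of > 20 ug/mL in this assay, at which 3 of the 3 values shown sit). In this assay compound 4 is therefore estimated to give 30 ug/mL, most probably reported again only as a limit.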

Compound 4, half-maximal inhibitory concentration: > 20 ug/mL
Compound 4 was reported as a limit; the forecaster's own chance of this, stated with the estimate: 85%; the middle value is on the limit's open side.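

In this assay compound 4 gives > 20 ug/mL, again a limit of the assay and not a number. Neither the step from compound 3 to compound 4 nor the step from compound 2 to compound 4 can be read, because the values share one limit: the limit of > 20 ug/mL in this assay, at which 4 of the 4 values shown sit.

The compounds shown leave open how strongly any of them inhibits, and whether exchanging benzyl for 2-hydroxyethyl or 2,4-dichlorophenyl for 4-bromophenyl changes that at all.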